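Triazolopyrimidine series: benzyl to cyclohexyl at the amine

The compounds below may be only part of what the source reports. "The series", "measured", "known", "first", "only" and "open" are said of these compounds alone.

Measured so far:
compound 1, `COc1ccc(CNc2ncc(C(=O)O)c3nc(-c4ccco4)nn23)cc1OC`: 159 nM
compound 2, `CCOC(=O)c1cnc(NCc2ccc(F)cc2)n2nc(-c3ccco3)nc12`: 46.3 nM

The two measured compounds share a core that differs at the ester or acid and at the amine substituent, so no single-point comparison between them exists; the numbers alone show that in an assay on CHO cells for displacement of a labelled ligand from adenosine receptor A3 (Homo sapiens) (on this read-out lower numbers stand for stronger inhibition and higher numbers for weaker inhibition), compound 2 gives 46.3 nM and compound 1 gives 159 nM, with compound 2 standing lowest of the two and compound 1 a step away that lies beyond the scatter.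

Compound 3, `CCOC(=O)c1cnc(NC2CCCCC2)n2nc(-c3ccco3)nc12`, is the next point and has not yet been measured in this assay. Relative to compound 2 the change is cyclohexyl in place of 4-fluorobenzyl on a nitrogen on an aromatic ring, which can also be read as (4-fluorobenzyl)amino to cyclohexylamino. Going by the values given here, no measured pair in this set isolates such a change, so there is no step on record to lean on.

The expectation for compound 3 is a somewhat higher number, a step of about a 3.2-fold higher number from compound 2 to compound 3 (0.51 log units; beyond the scatter), likely beyond the scatter but not large. Compound 3 is therefore estimated at 150 nM in this assay, within a range of 35 nM to 650 nM.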

Compound 3, inhibition constant: 131 nM
Estimate against measurement, compound 3: 1.1-fold (0.06 log units) above; the range from low to high includes it.
By their numbers in this assay, from the lowest: compound 2; then compounds 3 and 1 (each within the scatter of the next).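

Cyclohexyl in place of 4-fluorobenzyl on a nitrogen on an aromatic ring gives a 2.8-fold higher number from compound 2 to compound 3 (0.45 log units; beyond the scatter) in this assay, the first reading in the series of a change at one place with the rest of the structure held constant. The step is modest, so this position accepts a non-aromatic ring of carbon only while retaining measurable binding, although the pair favours the 4-fluorobenzyl group. The change removes the aromatic ring, the fluorine and the link to the ring all at once, so the step cannot be assigned to any one of them, and nothing on hand offers an explanation for it.

As far as these compounds go, whether plain benzyl without the fluorine, or cyclopentyl, would stand closer to compound 2 or to compound 3 remains open, as does the effect of a longer chain at this amine. The ester also remains unseparated from the amine substituent, and a carboxylic acid paired with cyclohexylamino or with (4-fluorobenzyl)amino would give a comparison at that single place.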